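Methylsulfanyl to piperazin-1-yl: a larger swap, still unmeasured

A few compounds are considered here, and "the series" means these few. Any claim that something is new, unique, unknown or untested is made for them only; others in the source may bear on it.

Among the compounds with values here, in a functional assay on U-87MG ATCC cells for inhibition, with U-87 MG (Homo sapiens) as the target, read by sulforhodamine B assay, with a stated time of 72 h (on this read-out lower numbers stand for an effect already at smaller amounts and higher numbers for an effect only at larger amounts of compound), compound 1 (`O=C(/C=C/c1ccc([N+](=O)[O-])o1)c1ccc(I)cc1`) gives 5200 nM and compound 2 (`CSc1ccc(C(=O)/C=C/c2ccc([N+](=O)[O-])o2)cc1`) gives 3900 nM as the only two numbers so far. Methylsulfanyl in place of iodo on an aromatic carbon gives a 1.3-fold lower number from compound 1 to compound 2 (0.12 log units; within the scatter) and so the two compounds stand level. The next structure is compound 3 (`O=C(/C=C/c1ccc([N+](=O)[O-])o1)c1ccc(N2CCNCC2)cc1`), with piperazin-1-yl in place of methylsulfanyl on an aromatic carbon, para to a large group (piperazin-1-yl in place of methylsulfanyl on an aromatic carbon). Within the data shown here, the single measured step, a 1.3-fold lower number from compound 1 to compound 2 (0.12 log units; within the scatter) and nothing more, is the only guide, and no measured compound carries such a ring. No step beyond the scatter is therefore expected in this assay but this expectation is loose. The expected change is a 1.1-fold lower number from compound 2 to compound 3 (0.05 log units; within the scatter) as an estimate only. For compound 3 the estimate is 3500 nM with 1000 nM to 12000 nM as the expected range.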

Compound 3, half-maximal effective concentration: 4900 nM
Compound 3: the middle estimate sits 1.4-fold (0.15 log units) below what was measured; low and high end bracket the measured number.
By their numbers in this assay, from the lowest: compounds 2, 3 and 1 (each within the scatter of the next).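

At this position, para to a large group, a far larger change than the first swap still leaves the number level in this assay: piperazin-1-yl in place of methylsulfanyl gives a 1.3-fold higher number from compound 2 to compound 3 (0.10 log units; within the scatter) and then piperazin-1-yl in place of iodo gives a 1.1-fold lower number from compound 1 to compound 3 (0.03 log units; within the scatter) as the second comparison. A group with no ring can thus give way to a six-membered non-aromatic ring with 2 hetero atoms and 1 hydrogen-bond donor without any step beyond the scatter, so iodo, methylsulfanyl and piperazin-1-yl all stand level here. Nothing available explains why such different groups give matching numbers.

Still open, going by these compounds, is whether any group at this position can move the number beyond the scatter, for example a carboxylic acid or a longer chain ending in an amine. On these data alone, it is equally open whether the hydrogen on the ring nitrogen of piperazin-1-yl matters, which a methyl group on that nitrogen would test.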